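Allylamide and cyclopropylamide series: whole-organism toxicity notes

The compounds below may be only part of what the source reports. "The series", "measured", "known", "first", "only" and "open" are said of these compounds alone.

Measured compounds:
compound 1, `C=CCNC(=O)/C(C)=C(/C)c1ccc(Cl)cc1`, a toxicity assay on the whole organism (strain Icem-CET (SPF Caw)) for cytotoxicity, with Mus musculus as the target (a higher number here means that more compound is needed for the effect, a lower number that less compound is needed), 400 mg/kg
compound 2, `C=CCNC(=O)/C(C)=C(/C)c1ccc(C)cc1`, this assay 400 mg/kg
compound 3, `C/C(C(=O)NC1CC1)=C(/C)c1ccc(Cl)cc1`, this assay 150 mg/kg

Compound 1 and compound 2 share one core and differ by methyl in place of chloro on an aromatic carbon. That change gives no change at the digits printed from compound 1 to compound 2 (within the scatter), so within these two the aromatic substituent does not move the read-out. Compound 3 carries the other core, the cyclopropylamide; how the two cores differ is not broken down here. Compound 3 gives the lowest number of the three, and its gap to compound 1 and to compound 2 lies beyond the scatter.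

Compound 4, `C/C(C(=O)NC1CC1)=C(/C)c1ccc(C)cc1`, has not been measured in this assay. It differs from compound 3 by methyl in place of chloro on an aromatic carbon, the same kind of change as from compound 1 to compound 2, with place lines that read the same word for word. Because the earlier step was no change at the digits printed from compound 1 to compound 2 (within the scatter), the step from compound 3 to compound 4 is expected to be of the same size, that is no change at the digits printed from compound 3 to compound 4 (within the scatter). Among the compounds with values here, compound 4 is therefore estimated at 150 mg/kg, between 75 mg/kg and 300 mg/kg, resting on the single earlier pair only.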

Compound 4, dose for half-maximal effect: 150 mg/kg
Beside the measured number, compound 4's estimate shows no gap at the digits printed, within the range that was stated.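

In this assay, methyl in place of chloro on an aromatic carbon gives no change at the digits printed from compound 3 to compound 4 (within the scatter), and this step matches the one on the core of compound 1: the same change on two cores in this assay, no change at the digits printed (within the scatter) from compound 1 to compound 2 and no change at the digits printed (within the scatter) from compound 3 to compound 4, 1.0-fold (0.00 log units) apart, within the scatter of two such steps. For this one exchange at this one place, the result therefore carries from one core to the other in the two cores shown. It does not show that the exchange would stay silent on a further core, and as neither step has a size beyond the scatter, the pairs do not test whether a real shift in the read-out would carry across cores.

As far as these compounds go, whether other groups at that place, such as a methoxy group, a nitrile or an amine, would also leave this assay unmoved remains open. Also open is what a longer chain on the amide nitrogen would do on either aromatic substitution, since only the allyl and cyclopropyl amides are shown.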